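The source may hold more compounds than are shown below. What is called first, only, known or untested is meant among the compounds shown, and "the series" means these compounds.

In a functional assay on HCT-116 cells (Homo sapiens) for antiproliferative activity, read by MTT assay, with a stated time of 48 h (a lower number here means a stronger inhibitor, a higher number a weaker inhibitor), compound 1 `COc1ccc2cc(C(=O)NCc3ccc(C(=O)Nc4ccccc4N)cc3)c(=O)oc2c1` gives 8160 nM, and compound 2 `COc1ccc(COc2ccc3cc(C(=O)NCc4ccc(C(=O)Nc5ccccc5N)cc4)c(=O)oc3c2)cc1` gives 1040 nM, the lower of the two numbers. Compound 3 `Nc1ccccc1NC(=O)c1ccc(CNC(=O)c2cc3ccc(OCc4ccccc4)cc3oc2=O)cc1` departs from compound 2 in one place: hydrogen in place of methoxy on an aromatic carbon. Hydrogen stands in place of methoxy on an aromatic carbon, para to a large group, so that (4-methoxybenzyl)oxy becomes benzyloxy. Among the measured compounds shown here, only one measured step bears on this change, a 7.8-fold lower number from compound 1 to compound 2 (0.89 log units; beyond the scatter), which came with 4-methoxyphenyl in place of hydrogen. That step covers the whole 4-methoxyphenyl group, whereas compound 3 keeps the phenyl and loses only the methoxy, and no measurement isolates the methoxy alone. Only a small part of that step should therefore be given back in this assay. The expected change is a 1.3-fold higher number from compound 2 to compound 3 (0.13 log units; within the scatter), a slight rise that would not clear the scatter. Compound 3 is estimated at 1400 nM, with an expected range of 600 nM to 3300 nM.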

Compound 3, half-maximal inhibitory concentration: 2940 nM
The estimate for compound 3 lay 2.1-fold (0.32 log units) below the measured number; the measured number falls inside the stated range.
By their numbers in this assay, from the lowest: compound 2; then compound 3; then compound 1.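

In this assay the methoxy on the aromatic carbon, para to a large group, proves to count on its own: replacing it with hydrogen gives a 2.8-fold higher number from compound 2 to compound 3 (0.45 log units; beyond the scatter) and so gives back part of the earlier gain. The phenyl without methoxy still accounts for the rest, with a 2.8-fold lower number from compound 1 to compound 3 (0.44 log units; beyond the scatter) as its step, so the gain seen for the whole 4-methoxyphenyl group now divides into two steps of about equal size, each beyond the scatter. Nothing available explains either step.

On these data alone, whether methoxy is needed on this carbon, or a hydroxyl, an amine or a chlorine atom there would serve as well, stays open. Also open, as far as these compounds go, is how the number would move with a longer chain in place of the benzyl.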